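The source may report more compounds than this note shows. Statements on the series, on what has been measured and on what is new or still open speak of the compounds shown alone.

Measured compounds:
compound 1 `CC(C)Nc1nc(NCc2ccco2)c2ccc(Cl)cc2n1`; compound 2 `CC(C)Nc1nc(NCc2ccco2)c2c(Cl)cccc2n1`; compound 3 `Cc1ccc2c(NCc3ccco3)nc(NC(C)C)nc2c1`.

In an ADME assay on J774.A1 cells (Mus musculus) for cytotoxicity, read by MTT assay, with a stated time of 72 h (a higher number here means that more compound is needed for the effect, a lower number that less compound is needed), compound 2 gives 25000 nM. Compound 1 reaches only a limit of this assay, > 100000 nM. Compound 3 also reaches only a limit of this assay, > 33000 nM. The change methyl in place of chloro on an aromatic carbon gives the step that the two limits leave unreadable from compound 1 to compound 3; with both ends at a limit, the limit of > 100000 nM in this assay, at which 1 of the 3 values shown sits, and (the limit of > 33000 nM in this assay, at which 1 of the 3 values shown sits), its size cannot be read. Compound 2 and compound 1 have the same atoms joined differently; the difference between the two cores is not broken down here.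

Compound 4 `Cc1cccc2nc(NC(C)C)nc(NCc3ccco3)c12` is not yet measured in this assay. It differs from compound 2 by methyl in place of chloro on an aromatic carbon, the same kind of change as from compound 1 to compound 3, though here ortho to a fused ring and meta to a fused ring rather than meta to a fused ring and para to a fused ring. Among the compounds with values here, compound 2 supplies the only number, 25000 nM, so only a small step is expected, a 1.6-fold higher number from compound 2 to compound 4 (0.20 log units; within the scatter), with wide uncertainty. Compound 4 is estimated at 40000 nM, between 15000 nM and 150000 nM.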

Compound 4, half-maximal effective concentration: 20000 nM
Estimate against measurement, compound 4: 2.0-fold (0.30 log units) above, within the range that was stated.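

On the core of compound 2, methyl in place of chloro on an aromatic carbon, ortho to a fused ring and meta to a fused ring, gives in this assay a 1.3-fold lower number from compound 2 to compound 4 (0.10 log units; within the scatter), so the two groups cannot be told apart there. On the core of compound 1, the same change cannot be read, as both ends of the step are limits of the assay and not numbers. The result therefore holds for one core only and does not show that the change carries from one core to the other.

Left open is how an amine, a carboxylic acid or a longer chain on this aromatic carbon would read in this assay. Also open, on these data alone, is whether any such group would give a readable number on the core of compound 1.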